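This account rests on a few compounds, and the source may have more. Where it says the series, first, only, none or still open, it means among the compounds named here.

Compound 1 `COc1ccc(-c2[nH]c3ccccc3c2/C=C(\C#N)S(=O)(=O)c2ccccc2)cc1` and compound 2 `COc1ccc(-c2[nH]c3ccc(OC)cc3c2/C=C(\C#N)S(=O)(=O)c2ccccc2)cc1` share one core, and compound 2 carries a second methoxy on the bicyclic part of it. In an ADME assay on MRC5 cells (Homo sapiens) for cytotoxicity, read by MTT assay, with a stated time of 96 h (on this read-out higher numbers stand for an effect only at larger amounts of compound and lower numbers for an effect already at smaller amounts), compound 1 gives 73000 nM, while compound 2 gives 22000 nM. Going by the values given here, the single measured step, a 3.3-fold lower number from compound 1 to compound 2 (0.52 log units; beyond the scatter), is the only one recorded, so compound 2 holds the lowest of the two numbers, with compound 1 standing at the higher one.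

Compound 3 `COc1ccc2[nH]c(-c3ccccc3)c(/C=C(\C#N)S(=O)(=O)c3ccccc3)c2c1` differs from compound 2 in one place: hydrogen in place of methoxy on an aromatic carbon. Among the compounds with values here, the change is at a different ring from the one altered between compound 1 and compound 2, so the measured step bears on it only loosely; it shows that adding a methoxy moved the number downward by a modest amount, and so removing a methoxy might be expected to move it back upward, if at all, by a similar amount. For compound 3 the estimated result in this assay is therefore a 1.6-fold higher number from compound 2 to compound 3 (0.20 log units; within the scatter), giving an expected value of 35000 nM with a range from 12000 nM to 90000 nM.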

Compound 3, half-maximal effective concentration: 14000 nM
Compound 3: the middle estimate sits 2.5-fold (0.40 log units) above what was measured; measured number inside the range.
By their numbers in this assay, from the lowest: compounds 3 and 2 (each within the scatter of the next); then compound 1.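

In this assay, the change from 4-methoxyphenyl to phenyl gives a 1.6-fold lower number from compound 2 to compound 3 (0.20 log units; within the scatter) and so stays inside the scatter: at this place, on a six-membered aromatic ring of carbon only and para to a large group, hydrogen and methoxy cannot be told apart on this read-out. The earlier step, a 3.3-fold lower number from compound 1 to compound 2 (0.52 log units; beyond the scatter) for a methoxy on the bicyclic part of the shared core, lay beyond the scatter, so among these compounds only that methoxy is tied to a step larger than the scatter, and adding or removing a methoxy does not read the same at both places. No independent measurement bears on why the two places read differently.

What the compounds shown leave open is whether a different group at this place, such as an amine, a carboxylic acid or a longer chain like butoxy, would give a step beyond the scatter. Going by these compounds, both compound 2 and compound 3 also carry the methoxy on the bicyclic part, so it remains open whether the exchange of methoxy for hydrogen reads the same when that methoxy is absent.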